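Swapping a ring sulfur for oxygen beside a sulfonyl

This account rests on a few compounds, and the source may have more. Where it says the series, first, only, none or still open, it means among the compounds named here.

Three compounds share a pyrazoline-type core carrying a sulfonyl group, and they were tested in a functional assay, tested at 50 ug/mL; on this read-out higher numbers stand for a stronger effect at the one concentration tested and lower numbers for a weaker effect. Compound 1, `O=S(=O)(CC1=NCCS1)C1C(c2ccccc2)=NN(c2ccccc2)C1c1ccccc1`, is reported as "not active" (no number reported), so no number stands for it. Compound 2, `COc1ccc(C2=NN(c3ccccc3)C(c3ccc(C)cc3)C2S(=O)(=O)CC2=NCCO2)cc1`, gives 62.5%, and compound 3, `COc1ccc(C2=NN(c3ccccc3)C(c3ccc(C)cc3)C2S(=O)(=O)CC2=NCCS2)cc1`, gives 42.6%. Compound 2 and compound 3 differ in one place: a group of 5 heavy atoms (3 carbon, 1 nitrogen, 1 oxygen; one five-membered non-aromatic ring with 2 hetero atoms) in place of a group of 5 heavy atoms (3 carbon, 1 nitrogen, 1 sulfur; one five-membered non-aromatic ring with 2 hetero atoms), on a saturated chain carbon bound to a sulfonyl sulfur. That change produced a number 19.9 percentage points higher from compound 3 to compound 2 (beyond the scatter).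

Compound 4, `O=S(=O)(CC1=NCCO1)C1C(c2ccccc2)=NN(c2ccccc2)C1c1ccccc1`, has not yet been measured. It arises from compound 1 by the same change: a group of 5 heavy atoms (3 carbon, 1 nitrogen, 1 oxygen; one five-membered non-aromatic ring with 2 hetero atoms) in place of a group of 5 heavy atoms (3 carbon, 1 nitrogen, 1 sulfur; one five-membered non-aromatic ring with 2 hetero atoms), on a saturated chain carbon bound to a sulfonyl sulfur. The place is described in identical words for both pairs, so the change is the same; only the cores differ, and the difference between the core of compound 1 and the core of compound 3 is not broken down here. The change occurs twice among these compounds, once measured and once not.

Compound 1 gives no number to build from, so the starting point is uncertain, but compound 3 to compound 2 moved upward, which suggests a modest gain may also appear here. Compound 4 is therefore estimated at 20% in this assay, expected to fall between 0% and 45%.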

Compound 4, a percentage reported as activity, at one concentration (the size of the read-out at that concentration, not a potency): 44.4%
Compound 4: the middle estimate sits 24.4 percentage points below what was measured, within the range that was stated.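

In this assay, within the data shown here, compound 4 gives 44.4% but compound 1 has no number, so no step from compound 1 to compound 4 can be read. The compounds shown leave open how large the effect of swapping the ring sulfur for oxygen is on the core of compound 1. No measurement shown here explains the result for compound 4.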